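From Pyridin-3-yl to Isoquinolin-4-yl: an Untested Step

This account rests on a few compounds, and the source may have more. Where it says the series, first, only, none or still open, it means among the compounds named here.

Measured so far:
compound 1 `O[C@H](COCCOC[C@@H](O)Cc1cn(Cc2ccc(Oc3ccccc3)cc2)nn1)Cc1ccc(-c2ccccc2)cc1`: 3400 nM
compound 2 `O[C@H](COCCOC[C@@H](O)Cc1cn(-c2cccnc2)nn1)Cc1ccc(-c2ccccc2)cc1`: 46800 nM
compound 3 `COC1=C(OC)C(=O)C(CCCCCCCCCCCCCCCn2cc(C[C@H](O)COCCOC[C@@H](O)Cc3ccc(-c4ccccc4)cc3)nn2)=C(C)C1=O`: 1500 nM

In a functional assay on HCT-116 cells (Homo sapiens) for inhibition, read by MTT assay, with a stated time of 72 h (on this read-out higher numbers stand for weaker inhibition of growth and lower numbers for stronger inhibition of growth), compound 2 gives the highest number of the three, and its gaps to compound 1 and to compound 3 both lie beyond the usual scatter, so compound 2 is the weakest growth inhibitor measured here. Compound 4 `O[C@H](COCCOC[C@@H](O)Cc1cn(-c2cncc3ccccc23)nn1)Cc1ccc(-c2ccccc2)cc1` has not been measured. It differs from compound 2 in one place: isoquinolin-4-yl in place of pyridin-3-yl on an aromatic nitrogen. Going by the values given here, no measured pair shows this kind of change, so its effect is uncertain. Still, compound 1 carries a larger aromatic group at the same position and gives 3400 nM, which hints that more ring atoms there may lower the number. A modest improvement is expected, a 3.1-fold lower number from compound 2 to compound 4 (0.49 log units; beyond the scatter). Compound 4 is therefore estimated at 15000 nM, with a likely range from 5000 nM to 45000 nM.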

Compound 4, concentration for 50% growth inhibition: 17800 nM
Estimate against measurement, compound 4: 1.2-fold (0.07 log units) below, and the stated range covers the measured number.
By their numbers in this assay, from the lowest: compound 3; then compound 1; then compound 4; then compound 2.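

Swapping pyridin-3-yl for isoquinolin-4-yl gives the first direct reading at this position: in this assay the swap produces a 2.6-fold lower number from compound 2 to compound 4 (0.42 log units; beyond the scatter) and so a modest gain in growth inhibition. The entering group adds a six-membered aromatic ring of carbon only, while the count of hydrogen-bond acceptors and the absence of net charge stay the same. Nothing available explains this step. Going by these compounds, whether an amine or a carboxylic acid on the isoquinolin-4-yl group would shift the number further remains open. So does the effect of a methylene link between this group and the aromatic nitrogen.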